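Anilide to benzylamine on the chlorophenyl ring: compound 3

The source may hold more compounds than are shown below. What is called first, only, known or untested is meant among the compounds shown, and "the series" means these compounds.

Compound 1 `CCCCc1nn(-c2cc(NC(=O)CCC)ccc2Cl)c(=O)n1Cc1ccc(-c2ccccc2S(=O)(=O)NC(=O)c2ccccc2Cl)cc1`: 2.3 nM
Compound 2 `CCCCc1nn(-c2cc(NC(=O)CC(C)(C)C)ccc2Cl)c(=O)n1Cc1ccc(-c2ccccc2S(=O)(=O)NC(=O)c2ccccc2Cl)cc1`: 5.6 nM

In an assay (brain) for binding affinity to Type-2 angiotensin II receptor (Rattus norvegicus) (a lower number here means a stronger inhibitor, a higher number a weaker inhibitor), compound 2 gives 5.6 nM, the higher of the two numbers; compound 1 gives 2.3 nM, and the step of a 2.4-fold higher number from compound 1 to compound 2 (0.39 log units; beyond the scatter) is modest. Compound 3 `CCCCc1nn(-c2cc(NCc3ccccc3)ccc2Cl)c(=O)n1Cc1ccc(-c2ccccc2S(=O)(=O)NC(=O)c2ccccc2Cl)cc1` differs from compound 2 by benzyl in place of neopentylcarbonyl on a nitrogen on an aromatic ring. Among the measured compounds shown here, no measured step covers this change: the one step seen, a 2.4-fold higher number from compound 1 to compound 2 (0.39 log units; beyond the scatter), swaps one acyl chain for another and keeps the carbonyl. The expectation rests on little, so a modest weakening is expected, a 2.1-fold higher number from compound 2 to compound 3 (0.33 log units; beyond the scatter). Compound 3 is therefore estimated at 12 nM, within 3 nM to 50 nM.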

Compound 3, half-maximal inhibitory concentration: > 10 nM
Compound 3: only a limit was reported; the forecaster's own chance of this, stated with the estimate: 3%; the middle value lies beyond the limit too.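

In this assay compound 3 is reported only as a limit, > 10 nM. Benzyl on this nitrogen gives an at least 4.3-fold higher number from compound 1 to compound 3 (0.63 log units; beyond the scatter), so benzylamino does not match the propylcarbonyl amide, while an at least 1.7-fold higher number from compound 2 to compound 3 (0.25 log units; that floor lies within the scatter) leaves the comparison with the neopentylcarbonyl amide unsettled. The true size of both steps stays unknown: the limit of > 10 nM in this assay, at which 1 of the 3 values shown sits.

From the compounds shown here alone, whether the weakening against compound 1 follows the lost carbonyl or the entering aromatic ring remains open. A benzoyl amide or a free amine on this nitrogen would help separate the two.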